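A few compounds are considered here, and "the series" means these few. Any claim that something is new, unique, unknown or untested is made for them only; others in the source may bear on it.

Measured so far in an ADME assay on HeLa cells (Homo sapiens) for cytotoxicity (on this read-out lower numbers stand for higher toxicity in this test and higher numbers for lower toxicity in this test), with these results:
- compound 1 `CCN(CC)CN1C(=O)/C(=N/NC(=S)Nc2ccc(Cl)cc2)c2ccccc21` gives 9800 nM
- compound 2 `CCN(CC)CN1C(=O)/C(=N/NC(=S)Nc2ccc(C)cc2)c2ccccc21` gives 10700 nM

Compound 2 stands level with compound 1 in this assay since the two numbers lie within the scatter of each other. Next comes compound 3 `CCN(CC)CN1C(=O)/C(=N/NC(N)=S)c2ccccc21` with this change: hydrogen in place of 4-methylphenyl on an amide-type nitrogen (in words, hydrogen in place of 4-methylphenyl on an amide-type nitrogen). Within the data shown here, the single measured step (a 1.1-fold higher number from compound 1 to compound 2 (0.04 log units; within the scatter)) only swaps a substituent on the aromatic ring and keeps the ring, so it bears weakly here. Among the measured compounds shown here, no measured compound lacks that ring, and the direction therefore remains uncertain. A moderate move towards a higher number in this assay is still expected, as a loose working assumption. The estimated step is (a 1.9-fold higher number from compound 2 to compound 3 (0.27 log units; within the scatter)) with wide margins. For compound 3 the expected value is 20000 nM within an estimated range from 6000 nM to 60000 nM as a first guess.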

Compound 3, half-maximal cytotoxic concentration: > 100000 nM
Compound 3 was reported as a limit (the forecaster's own chance of this, stated with the estimate: 10%); at least 5.0-fold (0.69 log units) between middle value and limit.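

In this assay compound 3 gives > 100000 nM, which is a limit of the assay and not a number. Where swapping the substituent on the aromatic ring stayed within the scatter (a 1.1-fold higher number from compound 1 to compound 2 (0.04 log units; within the scatter)), removing the whole aryl group from the amide-type nitrogen does not: hydrogen in place of 4-methylphenyl gives an at least 9.3-fold higher number from compound 2 to compound 3 (0.97 log units; beyond the scatter), and hydrogen in place of 4-chlorophenyl gives an at least 10-fold higher number from compound 1 to compound 3 (1.00 log units; beyond the scatter). So this position tolerates the chloro-to-methyl swap but responds strongly to losing the ring, though the full size of both steps stays unknown, as compound 3 sits at a limit: the limit of > 100000 nM in this assay, at which 1 of the 3 values shown sits.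

The compounds shown leave open whether a methyl group or a longer alkyl chain on that nitrogen would read close to compound 1 and compound 2 or close to compound 3. Also open, from the compounds shown here alone, is whether an amine or a carboxylic acid on the aromatic ring would shift the number.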